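The source may report more compounds than this note shows. Statements on the series, on what has been measured and on what is new or still open speak of the compounds shown alone.

Measured compounds:
- compound 1, `O=C(CSc1nc(Nc2ccccc2)c2ccccc2n1)Nc1ccc(Br)cc1`, in a functional assay on MGC-803 cells (Homo sapiens) for inhibition, read by MTT assay, with a stated time of 72 h; a lower number here means a stronger inhibitor, a higher number a weaker inhibitor: 19300 nM
- compound 2, `O=C(CSc1nc(Nc2ccccc2)c2ccccc2n1)Nc1ccc(C(F)(F)F)cc1`, in this assay: 8670 nM
- compound 3, `C=CC(=O)Nc1cccc(NC(=O)CSc2nc(Nc3ccc(Br)cc3)c3ccccc3n2)c1`, in this assay: 11500 nM

Compounds 1 and 2 share one core and differ in one place: trifluoromethyl in place of bromo on an aromatic carbon. That change gave a 2.2-fold lower number from compound 1 to compound 2 (0.35 log units; beyond the scatter). Compound 3 carries a different core; the difference between the two cores is not broken down here. In this assay compound 3 gives a number that lies within the scatter of compound 2 and likewise within the scatter of compound 1, so no order among these three follows from compound 3 alone.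

Compound 4, `C=CC(=O)Nc1cccc(NC(=O)CSc2nc(Nc3ccc(C(F)(F)F)cc3)c3ccccc3n2)c1`, has not yet been measured. It differs from compound 3 in one place: trifluoromethyl in place of bromo on an aromatic carbon. The surroundings of the change read the same as for the step from compound 1 to compound 2, so this is the same change made on the core of compound 3. Among the compounds shown it occurs twice in all.

Because the change gave a 2.2-fold lower number from compound 1 to compound 2 (0.35 log units; beyond the scatter), a step of similar size is expected from compound 3 to compound 4 in this assay, namely a 2.1-fold lower number from compound 3 to compound 4 (0.32 log units; beyond the scatter). This rests on a single earlier instance, on a different core, so the expectation is loose. Compound 4 is estimated at 5500 nM, with a range from 2500 nM to 12000 nM.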

Compound 4, half-maximal inhibitory concentration: 12100 nM
Compound 4: the middle estimate sits 2.2-fold (0.34 log units) below what was measured; the whole stated range lies below it.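

On the core of compound 3, trifluoromethyl in place of bromo gave a 1.1-fold higher number from compound 3 to compound 4 (0.02 log units; within the scatter) in this assay, so the step beyond the scatter seen on the core of compound 1 did not recur as a step beyond the scatter on this second core. Set side by side, however, the two steps cannot be told apart: the same change on two cores in this assay, a 2.2-fold lower number (0.35 log units; beyond the scatter) from compound 1 to compound 2 and a 1.1-fold higher number (0.02 log units; within the scatter) from compound 3 to compound 4, 2.3-fold (0.37 log units) apart, within the scatter of two such steps

Among these compounds, the result therefore does not show that the change carries over from one core to the other, nor does it show that the core alters the effect of the change, since each core offers only a single pair and ordinary scatter could account for the gap between them.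

The compounds shown carry only bromo and trifluoromethyl at this place, so it remains open whether chloro, a methoxy group or a nitrile there would give steps that stand clear of the scatter on either core. Also open, on these data alone, is how the same change would behave on further cores, for example one bearing an amine or a carboxylic acid in place of the acrylamide group.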